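Hydroxy placement across the shared core

This account rests on a few compounds, and the source may have more. Where it says the series, first, only, none or still open, it means among the compounds named here.

Compound 1 `Oc1ccccc1-c1ccc2c(-c3cncnc3)cccc2c1` opens the series. In an assay for binding affinity to 17-beta-hydroxysteroid dehydrogenase type 2 (Homo sapiens), read by scintillation counting, with a stated time of 10 min, tested at 1 uM (a lower number here means less inhibition, a higher number more inhibition at the concentration tested (going by the name of the read-out)), compound 1 gives < 10%, which is a limit of the assay and not a number. Compound 2 `Oc1cccc(-c2ccc3c(-c4cncnc4)cccc3c2)c1` carries 3-hydroxyphenyl in place of 2-hydroxyphenyl on an aromatic carbon. In this assay compound 2 likewise gives < 10%, again a limit. The step that the two limits leave unreadable from compound 1 to compound 2 thus has no readable size. Compound 3 `Oc1ccc2cc(-c3ccccc3)ccc2c1-c1cncnc1` stands in this assay at < 10%, a limit as well. All values shown sit at one limit (the limit of < 10% in this assay, at which 3 of the 3 values shown sit). Compound 4 `Oc1ccc(-c2ccc3c(-c4cncnc4)c(O)ccc3c2)cc1` differs from compound 3 by hydroxy in place of hydrogen on an aromatic carbon. Among the measured compounds shown here, no measured step bears on this change, so no shift beyond the scatter is expected, an estimated step that the limit leaves unreadable from compound 3 to compound 4 in this assay. Compound 4 is estimated at 8% (0% to 22%).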

Compound 4, a percentage reported as inhibition, at one concentration (the size of the read-out at that concentration, not a potency): 22%
Estimate against measurement, compound 4: 14 percentage points below, and the stated range covers the measured number.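

Among the compounds shown here, the change from phenyl to 4-hydroxyphenyl gives a number at least 12 percentage points higher from compound 3 to compound 4 (beyond the scatter) in this assay, the first step with a readable size; the earlier steps cannot be read. Compound 4 gives 22%, a number and not a limit. Compound 1, compound 2 and compound 3 all remain at a limit of the assay: the limit of < 10% in this assay, at which 3 of the 4 values shown sit.

Open, from the compounds shown here alone, is whether a methoxy or an amine in place of this hydroxy would keep a readable number. Also open, going by these compounds, is whether the same change would give a readable step on the core of compound 1.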